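A few compounds are considered here, and "the series" means these few. Any claim that something is new, unique, unknown or untested is made for them only; others in the source may bear on it.

Measured so far:

compound 1, `CCOC(=O)C1=C(C)N/C(=N\C#N)NC1c1ccco1`: 27%
compound 2, `CC1=C(C(=O)OC(C)C)C(C2CCCC2)N/C(=N/C#N)N1`: 3%
compound 3, `CC1=C(C(=O)OC(C)C)C(C2CCCC2)NC(=O)N1`: 1%

In an assay on cells for displacement of a labelled ligand from adenosine receptor A1 (Homo sapiens), with a stated time of 60 min, tested at 1 uM (on this read-out lower numbers stand for less inhibition and higher numbers for more inhibition at the one concentration tested (going by the name of the read-out)), compound 1 gives 27%, the highest of the three numbers. The nearest is compound 2, whose 3% lies beyond the scatter below it. The furthest is compound 3, whose 1% also lies beyond the scatter below it. Compound 2 and compound 3 are within the scatter of each other, so nothing is said about their order.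

Compound 4, `CCOC(=O)C1=C(C)N/C(=N\C#N)NC1c1ccoc1`, differs from compound 1 in one place: furan-3-yl in place of furan-2-yl on a saturated ring carbon. Among the compounds with values here, no pair among the measured compounds shows this kind of change, so the size of its step in this assay has to be guessed. Moving the attachment point around a small aromatic ring without changing any atom is expected to give a modest step, probably a small drop or none beyond the scatter. For compound 4 the expected value in this assay is 20%, within 5% to 40%, which is the expected step of a number 7 percentage points lower from compound 1 to compound 4 (within the scatter).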

Compound 4, a percentage reported as inhibition, at one concentration (the size of the read-out at that concentration, not a potency): 28%
For compound 4 the middle estimate is 8 percentage points below the measured one; the range from low to high includes it.
By their numbers in this assay, from the lowest: compounds 3 and 2 (each within the scatter of the next); then compounds 1 and 4 (each within the scatter of the next).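

Swapping furan-2-yl for furan-3-yl on the saturated ring carbon gives, in this assay, a number 1 percentage points higher from compound 1 to compound 4 (within the scatter). At this position, then, which carbon of the furan carries the bond to the shared core makes no difference that this read-out can separate, at least for this one pair. No measurement shown gives a reason why the two furans read alike.

Going by these compounds, what stays open is whether a bigger change on this carbon, such as a phenyl ring or a longer chain, would move the number beyond the scatter. Also open, on these data alone, is whether compound 1 and compound 4 would still look alike in a full potency measurement, as this read-out covers a single concentration.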